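Methoxy to hydroxy: from compound 2 to compound 3

The source may hold more compounds than are shown below. What is called first, only, known or untested is meant among the compounds shown, and "the series" means these compounds.

Measured so far in a physicochemical assay, read by spectrophotometry, with a stated time of 40 min, tested at 100 uM; a lower number here means less inhibition, a higher number more inhibition at the concentration tested (going by the name of the read-out):
compound 1 `COc1ccc(F)c(CN2CN(CC(=O)O)c3ccc(C)cc3S2(=O)=O)c1` gives 18.9%
compound 2 `COc1ccc(CN2CN(CC(=O)O)c3ccc(C)cc3S2(=O)=O)cc1` gives 3.1%

Compound 2 stands lowest of the two numbers in this assay. For the measured compounds named here, the single measured step, a number 15.8 percentage points lower from compound 1 to compound 2 (beyond the scatter), exchanged the whole ring on the saturated chain carbon bound to the sulfonamide nitrogen, not a substituent on it. Compound 3 `Cc1ccc2c(c1)S(=O)(=O)N(Cc1ccc(O)cc1)CN2CC(=O)O` differs from compound 2 by hydrogen in place of methyl on an oxygen on an aromatic ring. Going by the values given here, no measured step bears directly on this change, so the step to compound 1 is only a loose guide; a step within the scatter is expected, a number 4.9 percentage points higher from compound 2 to compound 3 (within the scatter). Compound 3 is estimated at 8%, in the range 0% to 25%.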

Compound 3, a percentage reported as inhibition, at one concentration (the size of the read-out at that concentration, not a potency): 5.2%
For compound 3 the middle estimate is 2.8 percentage points above the measured one; measured number inside the range.
By their numbers in this assay, from the lowest: compounds 2 and 3 (each within the scatter of the next); then compound 1.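

In this assay, the change of methoxy to hydroxy gives a number 2.1 percentage points higher from compound 2 to compound 3 (within the scatter), so at this place on the aromatic ring, the methyl on the oxygen can go without a move beyond the scatter. The gap to the 2-fluoro-5-methoxyphenyl group persists with the 4-hydroxyphenyl group, as a number 13.7 percentage points lower from compound 1 to compound 3 (beyond the scatter) stands beside the earlier a number 15.8 percentage points lower from compound 1 to compound 2 (beyond the scatter). No measurement at hand explains these numbers.

As far as these compounds go, whether an amine or a carboxylic acid in place of the hydroxy would leave the number within the scatter remains open. So does how much of the gap to compound 1 belongs to its fluoro group alone.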